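The source may hold more compounds than are shown below. What is called first, only, known or untested is meant among the compounds shown, and "the series" means these compounds.

Three compounds share one core and differ in the benzyl group on the ring nitrogen and in the hydrazone arm. Compound 1, `CCCSc1nc(N/N=C/c2ccc(Cl)cc2)c2nnn(Cc3ccccc3)c2n1`, gives in a functional assay on ECa-109 cells (Homo sapiens) for antiproliferative activity, read by MTT assay, with a stated time of 72 h (a higher number here means a weaker inhibitor, a lower number a stronger inhibitor), only a limit, > 64000 nM. Compound 2, `CCCSc1nc(N/N=C(\C)c2ccccc2O)c2nnn(Cc3ccccc3Cl)c2n1`, likewise gives only the limit > 64000 nM in this assay. For the measured compounds named here, compound 3, `CCCSc1nc(N/N=C(\C)c2ccccc2O)c2nnn(Cc3ccc(F)cc3)c2n1`, is the sole member with a number, 21900 nM in this assay. The values of compound 1 and compound 2 are limits, as the limit of > 64000 nM in this assay, at which 2 of the 3 values shown sit, records. Going by the values given here, the one measured step, an at least 2.9-fold lower number from compound 2 to compound 3 (0.46 log units; beyond the scatter), shows that a change confined to the benzyl ring can shift the read-out beyond the scatter.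

Compound 4 is `CCCSc1nc(N/N=C(\C)c2ccccc2O)c2nnn(Cc3ccccc3)c2n1`. It differs from compound 3 by hydrogen in place of fluoro on an aromatic carbon. Among the compounds with values here, no measured step removes a halogen from this ring: the step from compound 2 to compound 3 trades one halogenated benzyl for another, and compound 1 carries a plain benzyl but also a different hydrazone arm, so its limit and the number of compound 3 show only that the two ends of the series sit apart. The expected step is a 1.8-fold higher number from compound 3 to compound 4 (0.26 log units; within the scatter), a weakening that may reach the limit. The estimate for compound 4 is 40000 nM, expected to lie between 15000 nM and 100000 nM.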

Compound 4, half-maximal inhibitory concentration: 11100 nM
The estimate for compound 4 lay 3.6-fold (0.56 log units) above the measured number, and the stated range ends above it.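

In this assay, hydrogen in place of fluoro at this ring position leaves the read-out within the scatter (a 2.0-fold lower number from compound 3 to compound 4 (0.30 log units; within the scatter)), so the plain benzyl and the 4-fluorobenzyl group of compound 3 cannot be told apart here, and the fluoro is shown not to be needed for a measurable number. With the same hydrazone arm, the plain benzyl of compound 4 stands clear of the chlorinated benzyl of compound 2 (an at least 5.7-fold lower number from compound 2 to compound 4 (0.76 log units; beyond the scatter)), which places the loss on the chlorinated ring of compound 2 rather than on halogen removal as such. With the plain benzyl held fixed, the hydrazone arm of compound 4 in place of that of compound 1 also gives a step beyond the scatter (an at least 5.7-fold lower number from compound 1 to compound 4 (0.76 log units; beyond the scatter)), the first to isolate the arm, and this step and the one before it both start from a limit: the limit of > 64000 nM in this assay, at which 2 of the 4 values shown sit.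

Going by these compounds, how far compound 1 and compound 2 truly lie from compound 4 stays open. Also open, on these data alone, is whether a methoxy group or an amine on the benzyl ring, or a carboxylic acid on the hydrazone arm, would keep the read-out where compound 3 and compound 4 sit.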